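Swapping a cyclohexyl ring for an open chain

A few compounds are considered here, and "the series" means these few. Any claim that something is new, unique, unknown or untested is made for them only; others in the source may bear on it.

- compound 1 `Cc1[nH]c2ccc(Cl)cc2c(=O)c1Cc1ccccc1` gives 2.79
- compound 2 `CCc1c(C)[nH]c2cc(OC)c(F)cc2c1=O` gives 1.2
- compound 3 `COc1cc2[nH]c(C)c(C3CCCCC3)c(=O)c2cc1Cl` gives 3.04

In a physicochemical assay for lipophilicity, at pH 7.4 (on this read-out higher numbers stand for higher lipophilicity and lower numbers for lower lipophilicity), compound 3 (3.04) cannot be told apart from compound 1 within the usual scatter, while compound 2 lies well below it, beyond the scatter. Compound 4 `C=C(CCCCC)c1c(C)[nH]c2cc(OC)c(Cl)cc2c1=O` keeps the rest of compound 3 and changes one group: a group of 7 heavy atoms (7 carbon; no ring) in place of a group of 6 heavy atoms (6 carbon; one six-membered non-aromatic ring of carbon only), on an aromatic carbon. Within the data shown here, no measured pair differs in just one place, so the estimate starts from compound 3 at 3.04 and expects a small rise in this assay, possibly no larger than the scatter. The expected change is a number 0.26 log units higher from compound 3 to compound 4 (within the scatter) on this scale. For compound 4 the estimated value is 3.3 (range 2.8 to 3.8).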

Compound 4, distribution coefficient: 3.58
For compound 4 the middle estimate is 0.28 log units below the measured one; the measured number falls inside the stated range.
By their numbers in this assay, from the lowest: compound 2; then compounds 1 and 3 (each within the scatter of the next); then compound 4.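

Replacing cyclohexyl on this aromatic carbon with the open group of 7 heavy atoms gives, in this assay, a number 0.54 log units higher from compound 3 to compound 4 (beyond the scatter). Among these compounds, this is the first comparison that isolates a single place, and it shows that the read-out responds to the group held here. No measurement available explains the rise.

Removing the ring, adding a carbon and adding a double bond all happen in this one step, so their shares cannot be separated. On these data alone, how a saturated heptyl chain, an amine or a carboxylic acid would behave at this position remains open.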